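The source may report more compounds than this note shows. Statements on the series, on what has been measured and on what is new or still open speak of the compounds shown alone.

For the measured compounds named here, in a functional assay on FM3A cells (Mus musculus) for antiproliferative activity, read by cell counting, with a stated time of 2 days (on this read-out higher numbers stand for weaker inhibition and lower numbers for stronger inhibition), compound 1 (`COc1cc(C(=O)c2sc(N(C)C)nc2N)cc(OC)c1OC`) gives 12000 nM as the only exact number so far. Compound 2 (`COc1ccccc1C(=O)c1sc(N2CCCC2)nc1N`) reads > 200000 nM and that is a limit, not a number. Compound 3 (`Nc1nc(N2CCCC2)sc1C(=O)c1ccc(Cl)cc1`) reads > 200000 nM and that too is a limit. Compound 3 thus stands at the limit of > 200000 nM in this assay, at which 2 of the 3 values shown sit, and has no exact place. Compound 4 (`Nc1nc(N2CCCC2)sc1C(=O)c1ccccc1`) has hydrogen in place of chloro on an aromatic carbon, para to a large group (hydrogen in place of chloro on an aromatic carbon). No measured pair sizes this change, so the step expected in this assay is none beyond the scatter, and no direction is claimed. The estimated step is a number no higher from compound 3 to compound 4 (the limit leaves the size open) at this stage. Compound 4 is estimated at 200000 nM with an expected range of 60000 nM to 300000 nM for now.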

Compound 4, half-maximal inhibitory concentration: > 200000 nM
Compound 4 ended at the assay's limit; the forecaster's own chance of this, stated with the estimate: 70%; the middle value lies on the limit itself.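

No new step can be read from compound 2 or compound 3 to compound 4, because all three stand at a limit: the limit of > 200000 nM in this assay, at which 3 of the 4 values shown sit.

The compounds shown leave open whether hydrogen, chloro and methoxy on an aromatic carbon differ at all in this read-out.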